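Swapping a hexyl chain for benzyl on compound 3

A few compounds are considered here, and "the series" means these few. Any claim that something is new, unique, unknown or untested is made for them only; others in the source may bear on it.

Values so far in a functional assay on MCF7 cells (Homo sapiens) for inhibition, read by fluorescence, with a stated time of 72 h; on this read-out higher numbers stand for weaker inhibition of growth and lower numbers for stronger inhibition of growth
- compound 1 `COc1ccc(Cn2cnc3c(Nc4cccc(Cl)c4)nc(N[C@H]4CC[C@H](N)CC4)nc32)cc1` gives 4800 nM
- compound 2 `CCCCCCn1cnc2c(Nc3ccc(O)cc3)nc(N[C@H]3CC[C@H](N)CC3)nc21` gives 3500 nM
- compound 3 `CCCCCCn1cnc2c(Nc3cccc(Cl)c3)nc(N[C@H]3CC[C@H](N)CC3)nc21` gives 2700 nM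

Compound 3 stands within the usual scatter of both other compounds, so the three cannot be ranked. Compound 4 `N[C@H]1CC[C@H](Nc2nc(Nc3cccc(Cl)c3)c3ncn(Cc4ccccc4)c3n2)CC1` is still unmeasured. It differs from compound 3 by phenyl in place of pentyl on a saturated chain carbon bound to an aromatic nitrogen, which is phenyl in place of pentyl on a saturated chain carbon bound to an aromatic nitrogen. The most relevant evidence is a 1.8-fold lower number from compound 1 to compound 3 (0.25 log units; within the scatter), a change at that same place, and it lies within the scatter. The other step, a 1.3-fold lower number from compound 2 to compound 3 (0.11 log units; within the scatter), concerns a nitrogen on an aromatic ring and bears less directly. The expected step is a 1.4-fold higher number from compound 3 to compound 4 (0.15 log units; within the scatter), with nothing expected beyond the scatter. For compound 4 the estimated value is 3800 nM, with an expected range from 1900 nM to 7500 nM.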

Compound 4, concentration for 50% growth inhibition: 3600 nM
Estimate against measurement, compound 4: 1.1-fold (0.02 log units) above, within the range that was stated.
By their numbers in this assay, from the lowest: compounds 3, 2, 4 and 1 (each within the scatter of the next).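

Read directly for the first time, hexyl to benzyl gives a 1.3-fold higher number from compound 3 to compound 4 (0.12 log units; within the scatter) in this assay, so at this place a chain and a ring-bearing group are not told apart. Hydrogen in place of methoxy on the benzyl ring gives a 1.3-fold lower number from compound 1 to compound 4 (0.12 log units; within the scatter), so that ring carries the methoxy or goes without it with no readable change. Nothing measured here offers an explanation for these results. Still open, from the compounds shown here alone, is whether a carboxylic acid, an amine at the chain end or a much longer chain would shift the number beyond the scatter.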